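Compound 4: swapping the trichlorophenyl ester

The source may hold more compounds than are shown below. What is called first, only, known or untested is meant among the compounds shown, and "the series" means these compounds.

Values in a functional assay on M21 cells (Homo sapiens) for antiproliferative activity, read by sulforhodamine B assay, with a stated time of 48 h (on this read-out higher numbers stand for weaker inhibition and lower numbers for stronger inhibition), follow.
compound 1 `Cc1cccc(OS(=O)(=O)c2ccc(N3CCN(C)C3=O)cc2)c1` gives 2300 nM
compound 2 `CCCN1CCN(c2ccc(S(=O)(=O)Oc3ccccc3OC)cc2)C1=O` gives > 100000 nM, which is a limit
compound 3 `CCCN1CCN(c2ccc(S(=O)(=O)Oc3cc(Cl)c(Cl)cc3Cl)cc2)C1=O` gives 15000 nM

Compound 3 gives 15000 nM, the higher of the two numbers, and compound 1 lies lower, at 2300 nM, a gap beyond the scatter. Compound 4 `CCCN1CCN(c2ccc(S(=O)(=O)Oc3cccc(C)c3)cc2)C1=O` carries 3-methylphenyl in place of 2,4,5-trichlorophenyl on an oxygen. Among the measured compounds shown here, the only measured change on that oxygen is an at least 6.6-fold lower number from compound 2 to compound 3 (0.82 log units; beyond the scatter), beyond the scatter but bounded by a limit. Compound 1 also carries 3-methylphenyl, so the expectation leans on its 2300 nM, although its chain on the shared core differs from the propyl of compound 4. The expected step is a 3.8-fold lower number from compound 3 to compound 4 (0.57 log units; beyond the scatter), towards stronger inhibition. For compound 4 the estimated value is 4000 nM, with an expected range of 900 nM to 18000 nM.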

Compound 4, half-maximal inhibitory concentration: 28000 nM
The estimate for compound 4 lay 7.0-fold (0.85 log units) below the measured number; the measured number lies above the stated range.
By their numbers in this assay, from the lowest: compound 1; then compounds 3 and 4 (each within the scatter of the next). At a limit, above all of these: compound 2.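

In this assay, a 1.9-fold higher number from compound 3 to compound 4 (0.27 log units; within the scatter) does not separate 3-methylphenyl from 2,4,5-trichlorophenyl on the oxygen bound to the sulfonyl sulfur. With 3-methylphenyl held, a 12-fold higher number from compound 1 to compound 4 (1.09 log units; beyond the scatter) places the large change on the chain of the shared core, methyl in compound 1 against propyl in compound 4. Compound 2 holds a limit, not a number, so an at least 3.5-fold lower number from compound 2 to compound 4 (0.55 log units; beyond the scatter) gives only a bound: the limit of > 100000 nM in this assay, at which 1 of the 4 values shown sits.

Open, on these data alone, is whether an amine on the aryl ester moves the number. Also open, as far as these compounds go, is whether a butyl chain on the core extends the chain trend.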